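Piperazine versus piperidine on the side chain: next compound

The source may hold more compounds than are shown below. What is called first, only, known or untested is meant among the compounds shown, and "the series" means these compounds.

Measured in a functional assay on HCT-116 cells (Homo sapiens) for cytotoxicity, read by MTT assay, with a stated time of 72 h; on this read-out higher numbers stand for weaker inhibition and lower numbers for stronger inhibition:
- compound 1 `CN1CCN(CCCCn2c3c(c4ccccc42)C(=O)c2c[n+]([O-])c4ccccc4c2C3=O)CC1` gives 10 nM
- compound 2 `O=C1c2c[n+]([O-])c3ccccc3c2C(=O)c2c1c1ccccc1n2CCCCN1CCCCC1` gives 200 nM

Of the two numbers, compound 2 holds the higher at 200 nM and so shows the weaker inhibition. The next compound is compound 3 `CN1CCN(CCCn2c3c(c4ccccc42)C(=O)c2c[n+]([O-])c4ccccc4c2C3=O)CC1`, which differs from compound 2 as follows: 4-methylpiperazin-1-yl in place of (piperidin-1-yl)methyl on a saturated chain carbon, three bonds along the chain from an aromatic nitrogen. Cut one bond further out, this reads 4-(piperidin-1-yl)butyl to 3-(4-methylpiperazin-1-yl)propyl, so ring and chain length change together.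

Among the compounds with values here, only one measured step bears on this: a 20-fold higher number from compound 1 to compound 2 (1.30 log units; beyond the scatter). It is large and beyond the scatter, and it has piperidin-1-yl in place of 4-methylpiperazin-1-yl, the opposite direction of the ring change here. A lower number is therefore expected for compound 3. Within the data shown here, no measured pair shows the effect of chain length alone, so the gain may be only partly kept, and a somewhat smaller step is expected. The step expected in this assay is an 8.0-fold lower number from compound 2 to compound 3 (0.90 log units; beyond the scatter). For compound 3 the estimated value is 25 nM, with an expected range of 6 nM to 100 nM.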

Compound 3, half-maximal inhibitory concentration: 560 nM
Estimate against measurement, compound 3: 22-fold (1.35 log units) below; the whole stated range lies below it.
By their numbers in this assay, from the lowest: compound 1; then compound 2; then compound 3.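

Within the data shown here, with 4-methylpiperazin-1-yl kept, moving from (4-methylpiperazin-1-yl)methyl to 4-methylpiperazin-1-yl on the saturated chain carbon, three bonds along the chain from an aromatic nitrogen, shortens the chain and gives a 56-fold higher number from compound 1 to compound 3 (1.75 log units; beyond the scatter) in this assay, so chain length at this position is a strong variable in its own right, which the ring-only comparison of the earlier compounds could not show. The combined change from 4-(piperidin-1-yl)butyl to 3-(4-methylpiperazin-1-yl)propyl gives a 2.8-fold higher number from compound 2 to compound 3 (0.45 log units; beyond the scatter), so 4-methylpiperazin-1-yl does not bring a lower number regardless of chain in these three compounds, and its advantage over piperidin-1-yl on the longer chain does not carry over to this combined change. No measured evidence here explains either step.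

Still open, as far as these compounds go, is how 3-(piperidin-1-yl)propyl would compare, since that group would show whether the ring preference holds on the shorter chain as well. Also open, from the compounds shown here alone, is whether a longer chain carrying 4-methylpiperazin-1-yl, or a morpholine ring on the chain of compound 1, would keep the number of compound 1 10 nM.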